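Configuration at the hydroxypropyl chain in an alkyne amide series

This account rests on a few compounds, and the source may have more. Where it says the series, first, only, none or still open, it means among the compounds named here.

Compound 1 `Cc1ccc(NC(=O)c2cccc(C(F)(F)F)c2)cc1C#Cc1nn(C[C@H](C)CO)c2ncnc(N)c12` has only a limit in an ADME assay on HepG2 cells (Homo sapiens) for antiproliferative activity, read by MTT assay, with a stated time of 72 h; on this read-out higher numbers stand for weaker inhibition and lower numbers for stronger inhibition: compound 1 gives > 10000 nM, which is a limit and not a number. Compound 2 `Cc1ccc(NC(=O)c2ccc(Cl)c(C(F)(F)F)c2)cc1C#Cc1nn(C[C@@H](C)CO)c2ncnc(N)c12` likewise gives > 10000 nM in this assay, again a limit. Among the measured compounds shown here, both values sit at the limit of > 10000 nM in this assay, at which 2 of the 2 values shown sit, so compound 2 stands with compound 1 at the edge of what this assay reports, and no step between measured compounds can be taken from these two.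

Compound 3 `Cc1ccc(NC(=O)c2ccc(Cl)c(C(F)(F)F)c2)cc1C#Cc1nn(C[C@H](C)CO)c2ncnc(N)c12` is not yet measured in this assay. It differs from compound 2 only in configuration as drawn the two compounds have the same atoms and bonds and differ only in configuration as drawn: 1 of 1 stereo elements differ; a stereocentre at a saturated chain carbon is drawn R in compound 2 and S in compound 3: a stereocentre at a saturated chain carbon is drawn R in compound 2 and S in compound 3. For the measured compounds named here, with no measured step to lean on, no shift beyond the scatter is expected for this change. Compound 3 is therefore expected to give 15000 nM in this assay, a range from 5000 nM to 50000 nM, with the step from compound 2 to compound 3 estimated as a step that the limit leaves unreadable from compound 2 to compound 3, most likely reported once more as a limit.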

Compound 3, half-maximal inhibitory concentration: > 10000 nM
Compound 3 was reported as a limit (the forecaster's own chance of this, stated with the estimate: 85%); the middle value does not contradict the limit.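

In this assay compound 3 gives > 10000 nM, which is a limit and not a number. No step from compound 2 or compound 1 to compound 3 can be read: the limit of > 10000 nM in this assay, at which 3 of the 3 values shown sit.

The compounds shown leave open whether the configuration at the saturated chain carbon or the chloro in place of hydrogen makes any difference to antiproliferative activity.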